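This account rests on a few compounds, and the source may have more. Where it says the series, first, only, none or still open, it means among the compounds named here.

Compound 1 `COc1ccc(N/C=C\C(=O)c2nc(-c3ccc(F)cc3)n3ccccc23)cc1` and compound 2 `O=C(/C=C\Nc1ccc(F)cc1)c1nc(-c2ccc(C(F)(F)F)cc2)n2ccccc12` share one core and were both tested in a functional assay on A549 cells (Homo sapiens) for cytotoxicity, read by MTT assay, with a stated time of 48 h; on this read-out higher numbers stand for weaker inhibition and lower numbers for stronger inhibition. In this assay, within the data shown here, compound 1 gives 19200 nM, the only plain number in the set. Compound 2 reaches only the limit of the assay, > 30000 nM, so for it no number is known; one of the two values shown sits at that limit (the limit of > 30000 nM in this assay, at which 1 of the 2 values shown sits). Compound 1 therefore stands as the sole measured anchor. Compound 3 `O=C(/C=C\Nc1ccc(Cl)cc1)c1nc(-c2ccc(F)cc2)n2ccccc12` differs from compound 1 in one place: chloro in place of methoxy on an aromatic carbon, para to a large group (chloro in place of methoxy on an aromatic carbon). Among the measured compounds shown here, no measured pair of this kind exists here, so the step cannot be read from data. The step from compound 1 to compound 3 is expected to be small, at most near the edge of the usual scatter, leaning towards weaker inhibition a 1.2-fold higher number from compound 1 to compound 3 (0.08 log units; within the scatter). Compound 3 is estimated at 23000 nM in this assay, within a range from 9000 nM to 55000 nM.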

Compound 3, half-maximal inhibitory concentration: 5090 nM
Estimate against measurement, compound 3: 4.5-fold (0.66 log units) above, and the stated range ends above it.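

The earlier compounds shown here gave no measured step at this position, but in this assay a 3.8-fold lower number from compound 1 to compound 3 (0.58 log units; beyond the scatter) follows the change from 4-methoxyphenyl to 4-chlorophenyl. This shows that the group on this aromatic carbon, para to a large group, can move the reading beyond the usual scatter, here towards stronger inhibition, even though the rest of the molecule stays the same. It is still only one pair, and nothing among the data shown explains why the number falls.

On these data alone, whether the lower number is particular to chloro remains open, since a bromo, a methyl or an amine at this same place would be needed to show how far the trend extends. As far as these compounds go, it is also open whether this change would have a similar effect on a different core.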